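Changing the aryl on the ring nitrogen: compound 3 to compound 4

The compounds below may be only part of what the source reports. "The series", "measured", "known", "first", "only" and "open" are said of these compounds alone.

Compound 1 `Cc1ccc(C)c(-n2nncc2CN2C(=O)C3(C(C#N)=C(N)Oc4c(N)cc5nc6ccccc6nc5c43)c3ccccc32)c1` gives in a functional assay on MCF7 cells (Homo sapiens) for antiproliferative activity, read by MTT assay, with a stated time of 48 h (a lower number here means a stronger inhibitor, a higher number a weaker inhibitor), only the limit > 50000 nM, not a number.
Compound 2 `CCc1cccc(CC)c1-n1nncc1CN1C(=O)C2(C(C#N)=C(N)Oc3c(N)cc4nc5ccccc5nc4c32)c2ccccc21` likewise reaches only the limit > 50000 nM in this assay.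
Among the compounds with values here, compound 3 `N#CC1=C(N)Oc2c(N)cc3nc4ccccc4nc3c2C12C(=O)N(Cc1cnnn1-c1cc(Cl)ccc1Cl)c1ccccc12` gives 33200 nM in this assay, the only number among the three.

Within the data shown here, compound 3 thus stands as the sole readable value. The steps of an at least 1.5-fold lower number from compound 1 to compound 3 (0.17 log units; that floor lies within the scatter) and an at least 1.5-fold lower number from compound 2 to compound 3 (0.17 log units; that floor lies within the scatter) each rest on a floor within the scatter, and the limit of > 50000 nM in this assay, at which 2 of the 3 values shown sit, leaves their true size open; a step that the two limits leave unreadable from compound 1 to compound 2 is likewise unreadable. Compound 4 `Cc1ccc(-n2nncc2CN2C(=O)C3(C(C#N)=C(N)Oc4c(N)cc5nc6ccccc6nc5c43)c3ccccc32)cc1Cl` differs from compound 3 by 3-chloro-4-methylphenyl in place of 2,5-dichlorophenyl on an aromatic nitrogen. All measured steps exchange this same aryl, yet none has a readable size, so the step expected from compound 3 to compound 4, a 1.2-fold higher number from compound 3 to compound 4 (0.08 log units; within the scatter), is small and of uncertain direction. Compound 4 is therefore estimated at 40000 nM, between 15000 nM and 100000 nM.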

Compound 4, half-maximal inhibitory concentration: > 50000 nM
Compound 4 ended at the assay's limit; the forecaster's own chance of this, stated with the estimate: 40%; middle value at least 1.2-fold (0.09 log units) away from the limit.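

In this assay, the change to 3-chloro-4-methylphenyl on the aromatic nitrogen gives an at least 1.5-fold higher number from compound 3 to compound 4 (0.17 log units; that floor lies within the scatter). Compound 4 gives > 50000 nM, which is a limit and not a number. Within the data shown here, compound 3 thus remains the only compound with a number, and the steps among compound 1, compound 2 and compound 4 cannot be read: the limit of > 50000 nM in this assay, at which 3 of the 4 values shown sit.

The compounds shown leave open how far these three lie past the limit. They also leave open whether an aryl carrying an amine or a carboxylic acid, or a longer alkyl chain in place of the aryl, would give a readable number.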